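Taking One Methoxy Away from Compound 2

A few compounds are considered here, and "the series" means these few. Any claim that something is new, unique, unknown or untested is made for them only; others in the source may bear on it.

Of the compounds shown here, two have been measured so far in a functional assay on A498 cells (Homo sapiens) for cytotoxicity; a lower number here means a stronger inhibitor of growth, a higher number a weaker inhibitor of growth. Compound 1 `CSc1ccc(C2=C(c3ccc(F)c(C)c3)C(=O)N3CCCC3C2)cc1` gives 300 nM and compound 2 `COc1ccc(C2=C(c3ccc(SC)cc3)CC3CCCN3C2=O)cc1OC` gives 8000 nM as its number. Compound 2 therefore holds the higher of the two numbers, and the gap lies beyond the scatter. Compound 3 `COc1ccc(C2=C(c3ccc(SC)cc3)CC3CCCN3C2=O)cc1` departs from compound 2 in one place, with hydrogen in place of methoxy on an aromatic carbon, ortho to a methoxy group and meta to a large group (hydrogen in place of methoxy on an aromatic carbon). For the measured compounds named here, no measured pair shows this change, so the expectation is loose. The only guide is that compound 1 at 300 nM shows lower numbers occur among these structures. A modest move toward a lower number is expected, with the estimated step (a 2.7-fold lower number from compound 2 to compound 3 (0.43 log units; beyond the scatter)) only a little beyond the scatter. For compound 3 the estimate is 3000 nM, with an expected range from 600 nM to 12000 nM.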

Compound 3, concentration for 50% growth inhibition: 800 nM
For compound 3 the middle estimate is 3.8-fold (0.57 log units) above the measured one, within the range that was stated.
By their numbers in this assay, from the lowest: compound 1; then compound 3; then compound 2.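

In this assay, the change of methoxy to hydrogen gives a 10-fold lower number from compound 2 to compound 3 (1.00 log units; beyond the scatter), the first measured view of this position, ortho to a methoxy group and meta to a large group, and it shows that the methoxy there is not required for growth inhibition among these structures. With 4-methoxyphenyl in place of 4-fluoro-3-methylphenyl on a double-bonded ring carbon, the record shows a 2.7-fold higher number from compound 1 to compound 3 (0.43 log units; beyond the scatter), so the second change moves the number the opposite way from the first. Nothing measured here accounts for either step.

The compounds shown leave open whether a hydroxyl, a chlorine atom or an amine on the same aromatic carbon would track hydrogen or methoxy. They also leave open what happens if the remaining methoxy group gives way to hydrogen.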